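From 1-methoxyethyl to 1-hydroxyethyl at compound 3

This account rests on a few compounds, and the source may have more. Where it says the series, first, only, none or still open, it means among the compounds named here.

In a functional assay on OCI-Ly3 cells (Homo sapiens) for antiproliferative activity (a lower number here means that less compound is needed, a higher number that more compound is needed for the effect), compound 1 `Cc1ncncc1NC(=O)Nc1cnc(-n2nccn2)c(Cl)c1` reads > 20000 nM as a limit of the assay, not a number. Compound 3 `COC(C)c1c(NC(=O)Nc2cnc(-n3nccn3)c(Cl)c2)cnc2ccccc12` gives 620 nM as the lower of the two actual numbers, and compound 2 `O=C(Nc1cnc(-n2nccn2)c(Cl)c1)Nc1cnc2ccccc2c1C1CCCC1` gives 7020 nM as the other. Compound 4 `CC(O)c1c(NC(=O)Nc2cnc(-n3nccn3)c(Cl)c2)cnc2ccccc12` differs from compound 3 by hydrogen in place of methyl on an oxygen on a saturated carbon and turns methoxy to hydroxy. Within the data shown here, one measured step bears on this group: an 11-fold lower number from compound 2 to compound 3 (1.05 log units; beyond the scatter) came from replacing cyclopentyl with the whole 1-methoxyethyl, so it is large but only an indirect guide. The estimated step is a 1.5-fold higher number from compound 3 to compound 4 (0.16 log units; within the scatter) and is expected to stay within the scatter. Compound 4 is expected near 900 nM with an estimated range of 280 nM to 3200 nM in this assay here.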

Compound 4, half-maximal effective concentration: 730 nM
Compound 4: middle estimate off by 1.2-fold (0.09 log units), on the high side; measured number inside the range.
By their numbers in this assay, from the lowest: compounds 3 and 4 (each within the scatter of the next); then compound 2. At a limit, above all of these: compound 1.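

In this assay, hydrogen in place of methyl on an oxygen on a saturated carbon leaves the reading within the scatter, with a 1.2-fold higher number from compound 3 to compound 4 (0.07 log units; within the scatter). Methoxy and hydroxy therefore read alike here, and 1-hydroxyethyl joins 1-methoxyethyl in reading lower than cyclopentyl, with a 9.6-fold lower number from compound 2 to compound 4 (0.98 log units; beyond the scatter). Nothing shown gives a cause for either step. From the compounds shown here alone, it remains open whether an amine in place of hydroxy, or a longer chain on the oxygen, would also stay within the scatter of compound 3 in this assay.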